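The compounds below may be only part of what the source reports. "The series", "measured", "known", "first", "only" and "open" are said of these compounds alone.

In a functional assay on CHO-K1 cells for antagonist activity at melanin-concentrating hormone receptor 1 (Homo sapiens), read by inositol phosphate accumulation (on this read-out higher numbers stand for weaker inhibition and lower numbers for stronger inhibition), compound 3 `Cc1nc(N2CCN(C(=O)C3CC3)CC2)nc2ccc(NC(=O)COc3ccc(OC(F)(F)F)cc3)cc12` gives 30 nM, the lowest number among the three measured compounds. Compound 2 `CCC1(O)CCN(c2nc(C)c3cc(NC(=O)COc4ccc(OC(F)(F)F)cc4)ccc3n2)CC1` gives 59 nM, and the step of a 2.0-fold lower number from compound 2 to compound 3 (0.29 log units; within the scatter) lies within the scatter, so the two cannot be ordered. Compound 1 `Cc1nc(N2CCN(C3CCOCC3)CC2)nc2ccc(NC(=O)COc3ccc(Cl)cc3)cc12` gives 115 nM, a number beyond the scatter from compound 3, though the two structures differ in two places.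

Compound 4 `Cc1nc(N2CCN(C3CCOCC3)CC2)nc2ccc(NC(=O)COc3ccc(OC(F)(F)F)cc3)cc12` differs from compound 3 by one change: oxan-4-yl in place of cyclopropylcarbonyl on an amine nitrogen in a ring. Among the compounds with values here, no measured step covers this change directly. The step from compound 2 to compound 3 shows that an exchange of the group on that amine nitrogen stayed within the scatter. Compound 1 carries the same 4-(oxan-4-yl)piperazin-1-yl group as compound 4 but a different aryl group, and its number sits well above compound 3; how much of that gap belongs to the piperazine substituent cannot be told from the data.

The expectation is therefore a modest rise, a 2.0-fold higher number from compound 3 to compound 4 (0.30 log units; within the scatter), with wide uncertainty. Compound 4 is estimated at 60 nM in this assay, within a range from 20 nM to 180 nM.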

Compound 4, half-maximal inhibitory concentration: 31 nM
Compound 4: middle estimate off by 1.9-fold (0.29 log units), on the high side; measured number inside the range.
By their numbers in this assay, from the lowest: compounds 3, 4, 2 and 1 (each within the scatter of the next, the first and the last beyond it).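

In this assay, oxan-4-yl and cyclopropylcarbonyl on the amine nitrogen in a ring cannot be told apart (a 1.0-fold higher number from compound 3 to compound 4 (0.01 log units; within the scatter)), even though one group brings a six-membered ring with a hetero atom and the other a three-membered ring of carbon with a double bond outside aromatic rings. The exchange of the whole group on the aromatic carbon also stays inside the scatter (a 1.9-fold lower number from compound 2 to compound 4 (0.28 log units; within the scatter)), so the three compounds that carry trifluoromethoxy, compound 2, compound 3 and compound 4, cannot be ordered. Within the data shown here, compound 4 also gives the first comparison that changes the aryl group alone, and trifluoromethoxy in place of chloro is the only step here that lies beyond the scatter (a 3.7-fold lower number from compound 1 to compound 4 (0.57 log units; beyond the scatter)), a modest step seen in this single pair.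

The compounds shown leave open whether a free amine, a carboxylic acid or a longer chain on that amine nitrogen would also leave the number within the scatter, and whether the step from chloro to trifluoromethoxy recurs with cyclopropylcarbonyl or 4-ethyl-4-hydroxypiperidin-1-yl in place of the oxan-4-yl piperazine. Nothing measured alongside these numbers accounts for any of these steps.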